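A few compounds are considered here, and "the series" means these few. Any claim that something is new, unique, unknown or untested is made for them only; others in the source may bear on it.

Measured compounds in a functional assay on MCF7 cells (Homo sapiens) for cytotoxicity, read by MTT assay, with a stated time of 4 days; a lower number here means a stronger inhibitor, a higher number a weaker inhibitor:

Compound 1, `C=C1C(=O)[C@]23C[C@@]1(O)CC[C@H]2c1ccc(OS(=O)(=O)c2ccc(C)cc2)c(C)c1[C@@H]3Cn1cc(-c2ccc(Br)cc2)nn1`: compound 1 gives 250 nM.
Compound 2, `C=C1C(=O)[C@]23C[C@@]1(O)CC[C@H]2c1ccc(OS(=O)(=O)c2ccc(C)cc2)c(C)c1[C@@H]3Cn1cc(-c2ccc(F)cc2)nn1`: compound 2 gives 330 nM.

Among the compounds with values here, compound 2 holds the higher of these two numbers, but its only neighbour, compound 1, sits close by: the step from one to the other, a 1.3-fold higher number from compound 1 to compound 2 (0.12 log units; within the scatter), is within the scatter, so on these two numbers the compounds are not told apart.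

Compound 3, `C=C1C(=O)[C@]23C[C@@]1(O)CC[C@H]2c1ccc(OS(=O)(=O)c2ccc(C)cc2)c(C)c1[C@@H]3Cn1cc(-c2ccc(C)cc2)nn1`, is the next compound. It differs from compound 2 in one place: methyl in place of fluoro on an aromatic carbon.

Within the data shown here, only one measured step bears on this change. It also swapped one small group for another on an aromatic carbon of the same ring, and it came out as a 1.3-fold higher number from compound 1 to compound 2 (0.12 log units; within the scatter), a step within the scatter. With that single precedent and no other comparison, no shift beyond the scatter is expected in this assay in either direction.

Compound 3 is therefore estimated to give 300 nM, with a range from 150 nM to 650 nM, which means an expected step of a 1.1-fold lower number from compound 2 to compound 3 (0.04 log units; within the scatter).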

Compound 3, half-maximal inhibitory concentration: 320 nM
The estimate for compound 3 lay 1.1-fold (0.03 log units) below the measured number; the measured number falls inside the stated range.
By their numbers in this assay, from the lowest: compounds 1, 3 and 2 (each within the scatter of the next).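

Until now, this position had been compared only between two halogens, bromo and fluoro. Compound 3 adds a carbon group at the same aromatic carbon, and in this assay the result is a 1.0-fold lower number from compound 2 to compound 3 (0.01 log units; within the scatter) and a 1.3-fold higher number from compound 1 to compound 3 (0.11 log units; within the scatter), so both steps lie within the scatter and fluoro, bromo and methyl cannot be told apart here. This means that, for these three groups on the 4-substituted phenyl ring, neither replacing a halogen with methyl nor the choice between the two halogens separates the compounds, although three compounds are too few to support a broader rule. Nothing available here explains why the three compounds read alike.

The compounds shown leave open whether a clear shift in this assay would appear with an amine, a carboxylic acid or a longer chain such as butyl on this same carbon. They also leave open whether fluoro, bromo and methyl would still read alike on a different carbon of this ring, or with another change made elsewhere on the shared core.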